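Branching the amide chain: propyl versus isopropyl

This account rests on a few compounds, and the source may have more. Where it says the series, first, only, none or still open, it means among the compounds named here.

Measured compounds:
compound 1 `CC(=O)Nc1ccc(S(=O)(=O)Oc2ccccc2C(C)C)cc1` gives 12000 nM
compound 2 `CCCC(=O)Nc1ccc(S(=O)(=O)Oc2ccccc2C(C)C)cc1` gives 950 nM
compound 3 `CCCC(=O)Nc1ccc(S(=O)(=O)Oc2ccccc2I)cc1` gives 2000 nM

These numbers come from a functional assay on HT-1080 cells (Homo sapiens) for antiproliferative activity, read by sulforhodamine B assay, with a stated time of 48 h; a lower number here means a stronger inhibitor, a higher number a weaker inhibitor. Compound 2 has the lowest number of the three; the step from compound 2 to compound 3 reads a 2.1-fold higher number from compound 2 to compound 3 (0.32 log units; beyond the scatter), and the step from compound 1 to compound 2 reads a 13-fold lower number from compound 1 to compound 2 (1.10 log units; beyond the scatter). Compound 4 `CC(C)C(=O)Nc1ccc(S(=O)(=O)Oc2ccccc2C(C)C)cc1` differs from compound 2 only at the chain on the carbonyl carbon: isopropyl in place of propyl on a carbonyl carbon. Among the measured compounds shown here, of the measured steps, only the one from compound 1 to compound 2 touches this chain, and it grew the chain rather than rearranging it; nothing measured tests branching with the same atoms. Compound 4 is therefore expected to stay close to compound 2, with an estimated step of a 1.4-fold higher number from compound 2 to compound 4 (0.14 log units; within the scatter). The estimate for compound 4 is 1300 nM, within 500 nM to 3500 nM.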

Compound 4, half-maximal inhibitory concentration: 4900 nM
The estimate for compound 4 lay 3.8-fold (0.58 log units) below the measured number; measured number above the stated range.
By their numbers in this assay, from the lowest: compound 2; then compound 3; then compound 4; then compound 1.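

With the same atoms on the carbonyl carbon, a 5.2-fold higher number from compound 2 to compound 4 (0.71 log units; beyond the scatter) follows when isopropyl replaces propyl, so the arrangement of this chain matters and not only its size. Isopropyl still keeps part of the gain over methyl, as a 2.4-fold lower number from compound 1 to compound 4 (0.39 log units; beyond the scatter) shows, though less of it than propyl does. Nothing available explains why the branched chain falls short of the straight one. On these data alone, it remains open whether a longer chain such as butyl, or a cyclopropyl ring, would do better than propyl on this carbonyl carbon, and whether branching costs as much when iodo replaces the isopropyl on the aromatic carbon.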